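The source may report more compounds than this note shows. Statements on the series, on what has been measured and on what is new or still open speak of the compounds shown alone.

Measured so far:
compound 1, `O=C(CC1c2ccccc2N=C(SCCCCCN2CCCC2)N1c1ccccc1)NCc1ccc(F)cc1`: 57400 nM
compound 2, `CN(C)CCCCCSC1=Nc2ccccc2C(CC(=O)NCc2ccc(F)cc2)N1c1ccccc1`: 832000 nM
compound 3, `CN(C)CCCCCSC1=Nc2ccccc2C(CC(=O)NCc2ccccc2)N1c1ccccc1`: 13800 nM

Of the compounds shown here, three sharing one core have been tested in an assay on cells for inhibition of Voltage-dependent T-type calcium channel subunit alpha-1H (Homo sapiens), read by patch clamp; on this read-out higher numbers stand for weaker inhibition and lower numbers for stronger inhibition. Compound 2 gives 832000 nM, the highest of the three numbers. Compound 1, which carries pyrrolidin-1-yl in place of dimethylamino on a saturated chain carbon, five bonds along the chain from a sulfur, gives 57400 nM; the step of a 14-fold lower number from compound 2 to compound 1 (1.16 log units; beyond the scatter). Compound 3 differs from compound 2 by hydrogen in place of fluoro on an aromatic carbon. In this assay compound 3 gives 13800 nM, and the step of a 60-fold lower number from compound 2 to compound 3 (1.78 log units; beyond the scatter). Compound 3 thus stands lowest of the three, with compound 1 nearest and compound 2 furthest.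

Compound 4, `O=C(CC1c2ccccc2N=C(SCCCCCN2CCCC2)N1c1ccccc1)NCc1ccccc1`, has not yet been measured in this assay. It differs from compound 3 by pyrrolidin-1-yl in place of dimethylamino on a saturated chain carbon, five bonds along the chain from a sulfur. This is the same change that separates compound 2 from compound 1, made at the same place on the chain, and it occurs twice among these compounds. The earlier instance was a large step downward, a 14-fold lower number from compound 2 to compound 1 (1.16 log units; beyond the scatter), seen on the pair that carries fluoro on the aromatic ring.

On that basis compound 4 is expected to give a lower number than compound 3, with an estimated step of a 4.6-fold lower number from compound 3 to compound 4 (0.66 log units; beyond the scatter), because the same change gave a 14-fold lower number from compound 2 to compound 1 (1.16 log units; beyond the scatter) on the other pair. Among the measured compounds shown here, the expected value for compound 4 is estimated at 3000 nM, with a likely range from 700 nM to 13000 nM, wider than the earlier step alone would suggest since only one prior instance of the change exists and the two pairs differ on the aromatic ring.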

Compound 4, half-maximal inhibitory concentration: 7710 nM
Compound 4: middle estimate off by 2.6-fold (0.41 log units), on the low side; measured number inside the range.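

In this assay, pyrrolidin-1-yl in place of dimethylamino gives a 1.8-fold lower number from compound 3 to compound 4 (0.25 log units; within the scatter), so on the pair without fluoro this change cannot be told apart from repeat measurement, and the large step seen on the fluoro pair did not carry over in size: the same change on two cores in this assay, a 14-fold lower number (1.16 log units; beyond the scatter) from compound 2 to compound 1 and a 1.8-fold lower number (0.25 log units; within the scatter) from compound 3 to compound 4, 8.1-fold (0.91 log units) apart, beyond the scatter of two such steps Hydrogen in place of fluoro points the same way on both pairs, with a 7.4-fold lower number from compound 1 to compound 4 (0.87 log units; beyond the scatter) on the pyrrolidin-1-yl pair, but its size also depends on the rest of the molecule: the same change on two cores in this assay, a 60-fold lower number (1.78 log units; beyond the scatter) from compound 2 to compound 3 and a 7.4-fold lower number (0.87 log units; beyond the scatter) from compound 1 to compound 4, 8.1-fold (0.91 log units) apart, beyond the scatter of two such steps Both comparisons rest on the same four compounds, so they show that in this set the two changes do not simply add up and that a step measured on one core cannot be transferred at face value to another; they do not show why this is so, or whether it would hold beyond these compounds.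

The compounds shown leave open whether a piperidin-1-yl or morpholin-4-yl group, or a longer chain, would follow compound 1 and compound 4 or behave differently. Going by these compounds, it also remains open how chloro or methoxy in place of fluoro on the aromatic carbon would fare with either amine.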